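The source may hold more compounds than are shown below. What is called first, only, known or untested is meant among the compounds shown, and "the series" means these compounds.

Among the measured compounds shown here, in an ADME assay on the whole organism with Oryza sativa as the target, tested at 10 uM (on this read-out higher numbers stand for a weaker effect at the one concentration tested and lower numbers for a stronger effect), compound 3 `CCOC(=O)c1cccc(NC(=O)N[C@H](C)c2ccccc2)c1` gives 88%, the lowest of the three numbers measured so far. Its nearest neighbour is compound 2 `C[C@H](NC(=O)Nc1cccc(C(F)(F)F)c1)c1ccccc1`, which in this assay gives 92%, a difference within the scatter; the furthest is compound 1 `Cc1cccc(NC(=O)N[C@@H](C)c2ccccc2)c1`, which gives 100%, a gap beyond the scatter. For the measured compounds named here, the one measured step between single-change neighbours, a number 8 percentage points lower from compound 1 to compound 2 (within the scatter), is within the scatter and concerns trifluoromethyl in place of methyl on an aromatic carbon.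

Compound 4 `CCOC(=O)c1cccc(NC(=O)N[C@@H](C)c2ccccc2)c1` is next, and it differs from compound 3 as follows: the two compounds have the same atoms and bonds and differ only in configuration as drawn: 1 of 1 stereo elements differ; a stereocentre at a saturated chain carbon is drawn R in compound 3 and S in compound 4. Going by the values given here, none of the measured steps bears on this kind of change; the only step available, a number 8 percentage points lower from compound 1 to compound 2 (within the scatter), alters a substituent and says nothing about drawn configuration at the saturated chain carbon. The series therefore offers no guide to the direction, and the expectation rests on the value of compound 3 alone, with a wide allowance either way. Compound 4 is expected to give about 90% in this assay, within a range of 70% to 100%, which means an estimated step of a number 2 percentage points higher from compound 3 to compound 4 (within the scatter), likely no further than the scatter.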

Compound 4, a percentage reported as activity, at one concentration (the size of the read-out at that concentration, not a potency): 96%
Compound 4: middle estimate off by 6 percentage points, on the low side; low and high end bracket the measured number.
By their numbers in this assay, from the lowest: compounds 3, 2, 4 and 1 (each within the scatter of the next, the first and the last beyond it).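

In this assay, the change at the saturated chain carbon gives a number 8 percentage points higher from compound 3 to compound 4 (within the scatter), so reversing this stereocentre from R to S in the ethoxycarbonyl compounds does not carry the read-out beyond the scatter. With ethoxycarbonyl held in place, a number 4 percentage points higher from compound 2 to compound 4 (within the scatter) and a number 4 percentage points lower from compound 1 to compound 4 (within the scatter) show that replacing trifluoromethyl or methyl on an aromatic carbon also stays within the scatter, so neither step separates compound 4 from the earlier compound in its pair. The first of these comparisons isolates configuration alone, which the earlier compounds could not do, and its reading rests on a single structural fact: the fact that compounds 3 and 4 differ only in the configuration as drawn

The compounds shown leave open whether the same reversal of the stereocentre would also stay within the scatter with methyl or trifluoromethyl on the aromatic carbon. As far as these compounds go, it also remains open what a carboxylic acid or a nitrile would give in place of ethoxycarbonyl, or what a longer chain would give in place of the methyl group at the saturated chain carbon.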